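The source may report more compounds than this note shows. Statements on the series, on what has been measured and on what is new or still open speak of the compounds shown alone.

Measured compounds:
compound 1, `CCCn1c(=O)[nH]c2nc(-c3ccc(S(=O)(=O)N4CCN(c5ccc(Br)cc5)CC4)cc3)[nH]c2c1=O`, 0.0835 nM
compound 2, `CCCn1c(=O)[nH]c2nc(-c3ccc(S(=O)(=O)N4CCN(c5ccccc5C)CC4)cc3)[nH]c2c1=O`, 0.432 nM
compound 3, `CCCn1c(=O)[nH]c2nc(-c3ccc(S(=O)(=O)N4CCN(c5ccccc5F)CC4)cc3)[nH]c2c1=O`, 3.22 nM

In an assay on CHO cells for displacement of a labelled ligand from adenosine receptor A2b (Homo sapiens), read by scintillation counting, with a stated time of 75 min, in the presence of a further agent that is not named here (on this read-out lower numbers stand for stronger inhibition and higher numbers for weaker inhibition), compound 3 gives the highest number of the three. Compound 2 is nearest, with a 7.5-fold higher number from compound 2 to compound 3 (0.87 log units; beyond the scatter); compound 1 is furthest, with a 39-fold higher number from compound 1 to compound 3 (1.59 log units; beyond the scatter).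

Compound 4, `CCCn1c(=O)[nH]c2nc(-c3ccc(S(=O)(=O)N4CCN(Cc5ccc(Br)c(F)c5)CC4)cc3)[nH]c2c1=O`, has not been measured. It differs from compound 3 by 4-bromo-3-fluorobenzyl in place of 2-fluorophenyl on an amine nitrogen in a ring. Two of the measured steps bear on this. The step from compound 1 to compound 3 shows that exchanging a 4-bromophenyl for a 2-fluorophenyl raised the number greatly, a 39-fold higher number from compound 1 to compound 3 (1.59 log units; beyond the scatter), so restoring a bromine at the 4-position of the ring is expected to pull the number back down. The step from compound 2 to compound 3, a 7.5-fold higher number from compound 2 to compound 3 (0.87 log units; beyond the scatter), shows the fluoro substituent alone giving a modest rise. Among the measured compounds shown here, no measured pair covers a benzyl in place of a phenyl on the ring nitrogen, so that part of the change is uncharted, and the estimate is held wide. Compound 4 is therefore expected to show a lower number than compound 3 in this assay, estimated as a 4.0-fold lower number from compound 3 to compound 4 (0.60 log units; beyond the scatter). Compound 4 is expected at 0.8 nM, with a range from 0.12 nM to 5 nM.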

Compound 4, inhibition constant: 0.473 nM
Compound 4: the middle estimate sits 1.7-fold (0.23 log units) above what was measured; measured number inside the range.
By their numbers in this assay, from the lowest: compound 1; then compounds 2 and 4 (each within the scatter of the next); then compound 3.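

In this assay, among the compounds shown here, compound 4 shows that the amine nitrogen in a ring can carry a benzyl group as well as the phenyl groups of the earlier compounds, since 4-bromo-3-fluorobenzyl in place of 2-fluorophenyl gives a 6.8-fold lower number from compound 3 to compound 4 (0.83 log units; beyond the scatter). The new group does not match the 4-bromophenyl group, with a 5.7-fold higher number from compound 1 to compound 4 (0.75 log units; beyond the scatter), and it cannot be told apart from 2-methylphenyl, with a 1.1-fold higher number from compound 2 to compound 4 (0.04 log units; within the scatter). Nothing measured here gives a reason for these steps.

Because the benzyl group and its two halogens enter together, the share of each in the step remains unresolved. On these data alone, how an unsubstituted benzyl, a 4-bromobenzyl or a 2-phenylethyl group would behave on this nitrogen stays open.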